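Swapping Methyl for Chloro on the Pendant Phenyl

This account rests on a few compounds, and the source may have more. Where it says the series, first, only, none or still open, it means among the compounds named here.

The account opens with compound 1 `NC(=S)N/N=C/c1ccc2ccccc2n1`, the parent with only hydrogen on the amide-type nitrogen; in a functional assay on HeLa cells (Homo sapiens) for antiproliferative activity, read by sulforhodamine B assay, with a stated time of 72 h (on this read-out lower numbers stand for stronger inhibition and higher numbers for weaker inhibition), compound 1 gives 960 nM. Compound 2 `Cc1ccccc1NC(=S)N/N=C/c1ccc2ccccc2n1` carries a 2-methylphenyl there, and in this assay compound 2 gives only a limit of the assay, > 100000 nM (the limit of > 100000 nM in this assay, at which 1 of the 3 values shown sits). Compound 3 `Cc1ccc(NC(=S)N/N=C/c2ccc3ccccc3n2)cc1` carries a 4-methylphenyl and in this assay gives 86000 nM, the highest of the two numbers reported, with a 90-fold higher number from compound 1 to compound 3 (1.95 log units; beyond the scatter) separating it from the parent. The comparison an at least 1.1-fold lower number from compound 2 to compound 3 (0.06 log units; that floor lies within the scatter) leaves the two aryl analogues indistinguishable.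

Compound 4 `S=C(N/N=C/c1ccc2ccccc2n1)Nc1ccc(Cl)cc1` differs from compound 3 by chloro in place of methyl on an aromatic carbon, on an aromatic carbon of a six-membered aromatic ring of carbon only, para to a large group. For the measured compounds named here, no measured step alters a substituent on that ring; the only relevant ones are a 90-fold higher number from compound 1 to compound 3 (1.95 log units; beyond the scatter), a large loss on attaching any aryl, and an at least 1.1-fold lower number from compound 2 to compound 3 (0.06 log units; that floor lies within the scatter), within the scatter. The author therefore expects a step of a 1.1-fold lower number from compound 3 to compound 4 (0.03 log units; within the scatter), not beyond the scatter. Compound 4 is estimated at 80000 nM, between 20000 nM and 250000 nM.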

Compound 4, half-maximal inhibitory concentration: > 100000 nM
Compound 4: a limit, no number (the forecaster's own chance of this, stated with the estimate: 35%); at least 1.2-fold (0.09 log units) between middle value and limit.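

In this assay compound 4 gives only a limit of the assay, > 100000 nM: the limit of > 100000 nM in this assay, at which 2 of the 4 values shown sit. On the ring itself, para to a large group, chloro in place of methyl gives an at least 1.1-fold higher number from compound 3 to compound 4 (0.06 log units; that floor lies within the scatter), so this change brings no return towards the parent, and the step between compound 2 and compound 4 cannot be read. With an at least 100-fold higher number from compound 1 to compound 4 (2.01 log units; beyond the scatter), 4-chlorophenyl joins 2-methylphenyl and 4-methylphenyl as a third aryl group with a large loss, and no compound shown goes against this.

The compounds shown leave open whether a short alkyl chain on the amide-type nitrogen, rather than an aryl group, would stay near the level of compound 1, 960 nM. They also leave open whether an amine or a carboxylic acid on the ring would change the picture.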